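This account rests on a few compounds, and the source may have more. Where it says the series, first, only, none or still open, it means among the compounds named here.

Measured compounds:
compound 1, `CC1(C)OC2O[C@@H](Cc3cn4cc(Cl)ccc4nc3=O)C(OCc3ccccc3)C2O1`: > 1000000 nM
compound 2, `O=c1nc2ccc(Br)cn2cc1Cc1ccccc1`: 137000 nM

Both compounds were tested in a functional assay on SK-N-SH cells (Homo sapiens) for cytotoxicity, read by MTT assay, with a stated time of 24 h; on this read-out lower numbers stand for stronger inhibition and higher numbers for weaker inhibition. For compound 1 the result of > 1000000 nM is a limit of the assay rather than a number. Among the compounds with values here, compound 2 gives 137000 nM in this assay, and this is the only number among the results. The remaining entry is the limit of > 1000000 nM in this assay, at which 1 of the 2 values shown sits. Within the data shown here, since no two measured compounds differ from each other in a single place, there is no measured step whose size could guide an expectation.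

Compound 3, `O=c1nc2ccc(Br)cn2cc1Cc1ccc(Cl)cc1`, has not yet been measured. It differs from compound 2 by chloro in place of hydrogen on an aromatic carbon. The compounds at hand give no indication of how this change affects the read-out, so the expected step is small, within the usual scatter, with no set direction. The step that this estimate means is a 1.2-fold lower number from compound 2 to compound 3 (0.10 log units; within the scatter). Compound 3 is therefore expected to give about 110000 nM in this assay, with a range from 40000 nM to 300000 nM.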

Compound 3, half-maximal inhibitory concentration: 940 nM
Estimate against measurement, compound 3: 120-fold (2.07 log units) above; measured number below the stated range.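

Until now no single change could be read in this series, and the first one is large: in this assay, chloro in place of hydrogen on an aromatic carbon gives a 150-fold lower number from compound 2 to compound 3 (2.16 log units; beyond the scatter). The change sits on a six-membered aromatic ring of carbon only, para to a large group, and it adds just 1 heavy atom, a chlorine, with no net charge, so this position clearly matters for the read-out and one small substitution here can move it far beyond the scatter. Nothing measured here tells why this one atom changes the number so much.

Going by these compounds, it remains open whether the lower number belongs to chloro itself or would also come with another group at the same place, such as fluoro, methyl, methoxy or an amine, and whether chloro on another carbon of this ring would do the same. A single step also cannot show whether this change would have a similar effect on a different core, such as that of compound 1.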